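Adding a Methoxy Group to Compound 2

The source may report more compounds than this note shows. Statements on the series, on what has been measured and on what is new or still open speak of the compounds shown alone.

Of the compounds shown here, three have so far been measured in a functional assay on MDA-MB-231 cells (Homo sapiens) for inhibition, read by MTT assay, with a stated time of 48 h; on this read-out higher numbers stand for weaker inhibition and lower numbers for stronger inhibition. Compound 1 `Fc1ccc(-n2c(S)nnc2Sc2nnc(-c3ccccc3)n2-c2ccccc2)cc1` gives 29700 nM, compound 3 `Sc1nnc(Sc2nnc(-c3ccccc3)n2-c2ccccc2)n1-c1ccc(Cl)cc1` gives 49700 nM, and compound 2 `Sc1nnc(CSc2nnc(-c3ccccc3)n2-c2ccccc2)n1-c1ccccc1` gives 8570 nM, the lowest of the three numbers and beyond the scatter from both others. For the measured compounds named here, the only measured step, a 1.7-fold higher number from compound 1 to compound 3 (0.22 log units; within the scatter), exchanges one halogen for another on that ring and remains within the scatter. Compound 4 `COc1ccc(-n2c(S)nnc2CSc2nnc(-c3ccccc3)n2-c2ccccc2)cc1` differs from compound 2 by methoxy in place of hydrogen on an aromatic carbon. Going by the values given here, no measured step involves a methoxy group; the halogen step only shows that a small change on this ring altered the number little. Compound 4 is therefore expected at 9000 nM, with a range from 4000 nM to 20000 nM. The step this estimate implies, a 1.1-fold higher number from compound 2 to compound 4 (0.02 log units; within the scatter), is expected to stay within the scatter.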

Compound 4, half-maximal inhibitory concentration: 29200 nM
Compound 4: the middle estimate sits 3.2-fold (0.51 log units) below what was measured, and the stated range ends below it.
By their numbers in this assay, from the lowest: compound 2; then compounds 4, 1 and 3 (each within the scatter of the next).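

In this assay, the change from phenyl to 4-methoxyphenyl gives a 3.4-fold higher number from compound 2 to compound 4 (0.53 log units; beyond the scatter), moving the number toward weaker inhibition. This shows that the number can respond to a group placed para to a large group on this ring, which the halogen exchange between compound 1 and compound 3 did not show. No measurement here accounts for this shift.

As far as these compounds go, it remains open whether a hydroxy group or an amine at this position would also weaken inhibition. From the compounds shown here alone, it is equally open whether the same methoxy group would have a similar effect on the core of compound 1.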